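A few compounds are considered here, and "the series" means these few. Any claim that something is new, unique, unknown or untested is made for them only; others in the source may bear on it.

Measured so far:
compound 1, `COc1ccccc1N1CCN(CCCNC(=O)Cc2c[nH]c3ccccc23)CC1` — 513 nM
compound 2, `COc1ccc2[nH]c(C(=O)NCCCN3CCN(c4ccccc4OC)CC3)cc2c1` — 1450 nM

Both numbers come from an assay on isolated protein (spleen, strain Sprague-Dawley) for antagonist activity at Alpha-1B adrenergic receptor (Rattus norvegicus), with a stated time of 20 min; on this read-out higher numbers stand for weaker binding and lower numbers for tighter binding. Compound 2 stands highest of the two; the nearest number is that of compound 1, lower by a gap that lies beyond the usual scatter of repeated measurements.

Compound 3, `COc1ccccc1N1CCN(CCCNC(=O)c2cc3cc(O)ccc3[nH]2)CC1`, has not yet been measured in this assay. It differs from compound 2 in a single place: hydrogen in place of methyl on an oxygen on an aromatic ring. Within the data shown here, no pair of measured compounds here shows this same change, so its size cannot be read from the data. A small step is expected, either within the scatter or only just beyond it, with no clear direction.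

Compound 3 is therefore expected to give about 1200 nM in this assay, within 400 nM to 3500 nM. That amounts to an expected step of a 1.2-fold lower number from compound 2 to compound 3 (0.08 log units; within the scatter).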

Compound 3, dissociation constant: 155 nM
Beside the measured number, compound 3's estimate is 7.7-fold (0.89 log units) above it; measured number outside the range, below it.
By their numbers in this assay, from the lowest: compound 3; then compound 1; then compound 2.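

In this assay the change from methoxy to hydroxy on the aromatic ring proves to be far from minor: removing one methyl gives a 9.4-fold lower number from compound 2 to compound 3 (0.97 log units; beyond the scatter) and so clearly tighter binding. The larger swap of (1H-indol-3-yl)methyl for 5-hydroxy-1H-indol-2-yl on the carbonyl carbon gives a 3.3-fold lower number from compound 1 to compound 3 (0.52 log units; beyond the scatter) and so places compound 3 ahead of both earlier compounds, although that step alters more of the structure and cannot be credited to the hydroxy alone. Nothing available here explains why the hydroxy compound binds more tightly.

From the compounds shown here alone, whether a free hydroxy is specifically required remains open, since an amine or a fluorine on the same ring carbon would be needed to test it. It is also unknown whether adding a hydroxy to the indole of compound 1 would tighten binding in the same way.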